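A few compounds are considered here, and "the series" means these few. Any claim that something is new, unique, unknown or untested is made for them only; others in the source may bear on it.

Compound 2 `Cc1ccc(-c2nn(-c3ccc(S(N)(=O)=O)cc3)cc2C(CC(=O)c2ccc(Cl)cc2)C(=O)c2ccc(F)cc2)cc1` gives 56.2% in a functional assay on the whole organism (strain Wistar albino) for inhibition, with Rattus norvegicus as the target, read by paw edema, with stated times of 1 h and 3 h, at a dose of 0.32 mmol/kg by the intraperitoneal route (on this read-out lower numbers stand for less inhibition and higher numbers for more inhibition at the one dose given (going by the name of the read-out)), the higher of the two numbers in hand. Compound 1 `COc1ccc(C(=O)C(CC(=O)c2ccc(Cl)cc2)c2cn(-c3ccc(Cl)cc3)nc2-c2ccc(C)cc2)cc1` gives 23.9% in this assay, a gap beyond the scatter, though the two compounds differ in more than one place, so no single step can be read from them. Compound 3 `COc1ccc(C(=O)C(CC(=O)c2ccc(Cl)cc2)c2cn(-c3ccc(S(N)(=O)=O)cc3)nc2-c2ccc(C)cc2)cc1` has not yet been measured. It differs from compound 2 by methoxy in place of fluoro on an aromatic carbon. With no comparable single change in hand, the step is expected to stay within the scatter, about a number 4.2 percentage points lower from compound 2 to compound 3 (within the scatter). Compound 3 is therefore estimated at 52% in this assay, within 36% to 66%.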

Compound 3, a percentage reported as inhibition, in the whole organism at one dose (the size of the read-out at that dose, not a potency): 61.1%
Estimate against measurement, compound 3: 9.1 percentage points below; the range from low to high includes it.
By their numbers in this assay, from the lowest: compound 1; then compounds 2 and 3 (each within the scatter of the next).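

Methoxy in place of fluoro on an aromatic carbon, para to a large group, gives a number 4.9 percentage points higher from compound 2 to compound 3 (within the scatter) in this assay, so this position accepts both 4-fluorophenyl and 4-methoxyphenyl without a step beyond the scatter. Sulfamoyl in place of chloro on an aromatic carbon gives a number 37.2 percentage points higher from compound 1 to compound 3 (beyond the scatter) and is the only single-place step here that exceeds the scatter. No measurement in hand accounts for either step. Going by these compounds, whether an amine or a carboxylic acid at the place of the fluoro and methoxy groups would hold the number stays open. So does whether the sulfamoyl step recurs with other groups at that place.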